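A few compounds are considered here, and "the series" means these few. Any claim that something is new, unique, unknown or untested is made for them only; others in the source may bear on it.

Measured compounds in an assay on isolated protein for agonist activity at Bile acid receptor (Homo sapiens), read by FRET; a lower number here means that less compound is needed, a higher number that more compound is needed for the effect:
- compound 1 `O=C(O)c1cccc([C@H]2C[C@@H]2c2ccc(OCc3c(-c4c(Cl)cccc4Cl)noc3C3CC3)cc2Cl)c1` gives 219 nM
- compound 2 `O=C(O)c1cccc(N2CC(O)(c3ccc(OCc4c(-c5c(Cl)cccc5Cl)noc4C4CC4)cc3Cl)C2)c1` gives 54 nM
- compound 3 `Cn1nc(C(=O)O)c2ccc(C3CC3c3ccc(OCc4c(-c5c(Cl)cccc5Cl)noc4C4CC4)cc3Cl)cc21` gives 13 nM

Compound 1 stands at the highest of the three numbers in this assay. Compound 2 sits at the nearest value, which is beyond the scatter away from compound 1, and compound 3 sits furthest from it, also beyond the scatter. All three share the same aryl ether portion and differ in the acid-bearing part and in the ring that joins the two halves.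

Compound 4 `O=C(O)c1cccc([C@@H]2C[C@H]2c2ccc(OCc3c(-c4c(Cl)cccc4Cl)noc3C3CC3)cc2Cl)c1` is the next compound. Its relation to compound 1 is as follows: the two compounds have the same atoms and bonds and differ only in configuration as drawn: 2 of 2 stereo elements differ (all stereocentres are inverted: mirror images); a stereocentre at a saturated ring carbon is drawn S in compound 1 and R in compound 4; a stereocentre at a saturated ring carbon is drawn S in compound 1 and R in compound 4. Compound 4 is therefore the mirror image of compound 1, with no change of atoms or bonds. Among the measured compounds shown here, no pair of mirror images has been measured in this set, so the size and direction of such a step here is not known from the data. Mirror images commonly differ in this assay by an amount well beyond the scatter, in either direction, and which of the two gives the lower number cannot be told from compound 1 alone. Since compound 1 gives 219 nM, the highest number of the set, the expected step from compound 1 to compound 4 is set at a 1.8-fold lower number from compound 1 to compound 4 (0.26 log units; within the scatter), with wide uncertainty in both directions. For compound 4 the estimate in this assay is 120 nM, within a range of 15 nM to 1000 nM.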

Compound 4, half-maximal effective concentration: 18 nM
The estimate for compound 4 lay 6.7-fold (0.82 log units) above the measured number; the measured number falls inside the stated range.
By their numbers in this assay, from the lowest: compounds 3 and 4 (each within the scatter of the next); then compound 2; then compound 1.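

Inverting both stereocentres at the saturated ring carbons gives a 12-fold lower number from compound 1 to compound 4 (1.09 log units; beyond the scatter) in this assay. This step can be put down to configuration alone, because nothing else separates the pair: the fact that compounds 1 and 4 differ only in the configuration as drawn. Among the compounds shown here, the earlier compounds differ from one another in more than one place and could not isolate any single change, so this pair is the first evidence that the drawn configuration at this position matters on its own.

On these data alone, compound 3 carries no drawn configuration at its saturated ring carbons, so whether the same preference holds with its acid-bearing part remains open. Also open, as far as these compounds go, is whether the preference survives replacing the carboxylic acid with a tetrazole or an amide, or adding a methyl group to the saturated ring.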